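Swapping the aryl group on a thienopyrimidine core: clearance outlook

The source may hold more compounds than are shown below. What is called first, only, known or untested is meant among the compounds shown, and "the series" means these compounds.

Measured so far:
compound 1, `CNc1nc(NCCCN(C)C)c2sc(-c3ccc(C(F)(F)F)cc3)cc2n1`, 14 uL/min
compound 2, `CNc1nc(NCCCN(C)C)c2sc(-c3ccc(OC)nc3)cc2n1`, 10 uL/min

Both compounds were run in an ADME assay (liver) for metabolic stability, with Liver microsome (Homo sapiens) as the target, read by LC-MS, using microsomes, tested at 1 uM; a lower number here means slower removal, a higher number faster removal of the compound. Compound 1 gives 14 uL/min and compound 2 gives 10 uL/min. Compound 2 has the lowest of the two numbers, but its nearest neighbour, compound 1, sits only within the scatter of repeated measurements, so the two cannot be told apart on these data.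

The next compound, compound 3, `CNc1nc(NCCCN(C)C)c2sc(-c3ccc(C(C)=O)cc3)cc2n1`, keeps the shared core and changes only the group attached to it: 4-acetylphenyl in place of 6-methoxypyridin-3-yl on an aromatic carbon. Going by the values given here, no measured pair shows the effect of such a swap, so the expectation can rest only on the two numbers in hand, which are close to each other across two rather different aryl groups.

For that reason the step is expected to be small, with no clear direction beyond the scatter: a 1.2-fold higher number from compound 2 to compound 3 (0.08 log units; within the scatter). Compound 3 is therefore estimated to give about 12 uL/min in this assay, within a range from 5 uL/min to 30 uL/min.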

Compound 3, intrinsic clearance in a liver preparation (reported as CLH), per the amount of preparation that the assay uses in the Liver microsome assay: 81 uL/min
Compound 3: the middle estimate sits 6.8-fold (0.83 log units) below what was measured; the measured number lies above the stated range.
By their numbers in the Liver microsome assay, from the lowest: compounds 2 and 1 (each within the scatter of the next); then compound 3.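

Under the Liver microsome assay the aryl group next to the ring sulfur can move the number a long way, with an 8.1-fold higher number from compound 2 to compound 3 (0.91 log units; beyond the scatter) for the whole aryl swap and a 5.8-fold higher number from compound 1 to compound 3 (0.76 log units; beyond the scatter) when only acetyl replaces trifluoromethyl on the phenyl ring, so the closeness of compound 1 and compound 2 does not extend to every aryl group at this position. Going by these compounds alone, the jump has no counterpart in a physicochemical assay for lipophilicity, read by HPLC, at pH 7.4 (a higher number here means a more lipophilic compound, a lower number a more polar compound), where compound 2 gives 2.8 and compound 3 gives 2.9 as two values within the scatter of each other, so this read-out does not separate the pair as the clearance numbers do. Nothing available here accounts for the higher clearance of compound 3.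

Within the data shown here, since compound 2 and compound 3 differ in both the ring and its substituent, only the step from compound 1 isolates the acetyl group itself. On these data alone, whether the effect belongs to the carbonyl of the acetyl group remains open, and a 1-hydroxyethyl group, an amide or a nitrile on the same phenyl ring would test that.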